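A few compounds are considered here, and "the series" means these few. Any claim that something is new, unique, unknown or untested is made for them only; others in the source may bear on it.

- Compound 1 `COc1ccc(-c2oc3c(CC=C(C)C)c(OCCCC(=O)O)cc(O)c3c(=O)c2O)cc1`: 12700 nM
- Compound 2 `COc1ccc(-c2oc3c(CC=C(C)C)c(OCC(=O)O)cc(O)c3c(=O)c2O)cc1`: 13500 nM

Going by the values given here, in a functional assay on MDA-MB-435S cells (Homo sapiens) for cytotoxicity, read by MTT assay (a lower number here means a stronger inhibitor, a higher number a weaker inhibitor), compound 1 gives 12700 nM and compound 2 gives 13500 nM, so compound 1 stands level with the only other measured compound, within the scatter. Compound 3 `COc1ccc(-c2oc3c(CC=C(C)C)c(OCCCC(=O)O)cc(O)c3c(=O)c2OCCCC(=O)O)cc1` differs from compound 1 as follows: 3-carboxypropyl in place of hydrogen on an oxygen on an aromatic ring. In words, hydroxy becomes 3-carboxypropoxy. Among the compounds with values here, the one measured step, a 1.1-fold higher number from compound 1 to compound 2 (0.03 log units; within the scatter), stayed within the scatter, but it alters an existing chain and adds none, so it is only a loose guide. The expected change is modest and towards a weaker number, a 1.6-fold higher number from compound 1 to compound 3 (0.20 log units; within the scatter). For compound 3, the estimated value is 20000 nM, with an expected range from 8000 nM to 50000 nM.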

Compound 3, half-maximal inhibitory concentration: 31100 nM
Compound 3: the middle estimate sits 1.6-fold (0.19 log units) below what was measured; the measured number falls inside the stated range.
By their numbers in this assay, from the lowest: compounds 1 and 2 (each within the scatter of the next); then compound 3.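

Replacing hydroxy with 3-carboxypropoxy gives a 2.4-fold higher number from compound 1 to compound 3 (0.39 log units; beyond the scatter) in this assay, so this oxygen, unlike the chain altered earlier, shows a change beyond the scatter when a new chain is added. The earlier step only altered an existing chain on a different oxygen, and it stayed within the scatter. Nothing available here explains this shift.

From the compounds shown here alone, what remains open is whether simply capping this oxygen is enough, or whether the chain and its carboxylic acid end matter. A methyl on the same oxygen, or a chain ending in an amine, would help separate these possibilities.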